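The source may report more compounds than this note shows. Statements on the series, on what has been measured and on what is new or still open speak of the compounds shown alone.

The study concerns the shared core of compound 1 `COc1ccccc1-c1cn(C[C@H](O)[C@H]2OC(=O)C(OCc3ccccc3)=C2OCc2ccccc2)nn1`, whose side chain ends in a five-membered aromatic ring with 3 nitrogen carrying a 2-methoxyphenyl group. In a functional assay on A549 cells (Homo sapiens) for antiproliferative activity, read by MTT assay, with a stated time of 72 h (a higher number here means a weaker inhibitor, a lower number a stronger inhibitor), compound 1 gives > 100000 nM, which is a limit of the assay and not a number. Compound 2 `CC(C)(C)OC(=O)N1CCN(C(=S)SCc2cn(C[C@H](O)[C@H]3OC(=O)C(OCc4ccccc4)=C3OCc3ccccc3)nn2)CC1` carries a different group on the same five-membered aromatic ring. In this assay compound 2 gives > 100000 nM, again a limit rather than a measured number. Among the measured compounds shown here, compound 1 thus stands at the limit of > 100000 nM in this assay, at which 2 of the 2 values shown sit, and no measured step separates it from any other compound in the set.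

Compound 3 `O=C1O[C@H]([C@@H](O)Cn2ccnn2)C(OCc2ccccc2)=C1OCc1ccccc1` has not yet been measured. It differs from compound 1 by hydrogen in place of 2-methoxyphenyl on an aromatic carbon. For the measured compounds named here, because both values seen so far sit at the limit of > 100000 nM in this assay, at which 2 of the 2 values shown sit, no direction for a step in this assay can be read from the data. The change is expected to produce no shift beyond the scatter, so compound 3 is expected to remain at the limit. The expected step of a number no higher from compound 1 to compound 3 (the limit leaves the size open) therefore amounts to none. Compound 3 is estimated at 100000 nM, within a range from 30000 nM to 300000 nM.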

Compound 3, half-maximal inhibitory concentration: > 100000 nM
Compound 3: no number, only a limit; the forecaster's own chance of this, stated with the estimate: 85%; the middle value lies on the limit itself.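

Compound 3 gives > 100000 nM in this assay, again a limit of the assay and not a number. No step from compound 1 to compound 3 can be read, because both stand at the same limit: the limit of > 100000 nM in this assay, at which 3 of the 3 values shown sit.

The compounds shown leave open which change to the shared core, if any, would bring a value inside the range of this assay.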